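A few compounds are considered here, and "the series" means these few. Any claim that something is new, unique, unknown or untested is made for them only; others in the source may bear on it.

Measured so far:
compound 1 `C[C@H](NC(=O)Cn1ccc(=O)[nH]c1=O)C(=O)N[C@@H](CCC(=O)O)C(=O)O` — 210000 nM
compound 2 `C[C@H](NC(=O)Cn1ccc(=O)[nH]c1=O)C(=O)NCC(=O)O` — > 301000 nM
compound 3 `C[C@H](NC(=O)Cn1ccc(=O)[nH]c1=O)C(=O)N[C@@H](CCCCN)C(=O)O` — > 243000 nM

Among the compounds with values here, in a functional assay on L6 cells (Rattus norvegicus) for cytotoxicity (a lower number here means a stronger inhibitor, a higher number a weaker inhibitor), compound 1 gives 210000 nM, the only number among the three values shown. The value of compound 2 is a limit of the assay, (the limit of > 301000 nM in this assay, at which 1 of the 3 values shown sits). The value of compound 3 is likewise a limit, (the limit of > 243000 nM in this assay, at which 1 of the 3 values shown sits).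

Compound 4 `CC(O)[C@H](NC(=O)[C@H](C)NC(=O)Cn1ccc(=O)[nH]c1=O)C(=O)O` has not been measured. It differs from compound 1 as follows: 1-hydroxyethyl in place of 2-carboxyethyl on a saturated chain carbon bound to an amide-type nitrogen and a carbonyl carbon. Within the data shown here, two measured steps bear on this change. Removal of the same 2-carboxyethyl group on a saturated chain carbon bound to an amide-type nitrogen and a carbonyl carbon gives an at least 1.4-fold higher number from compound 1 to compound 2 (0.15 log units; that floor lies within the scatter). Exchange within that side chain gives an at least 1.1-fold higher number from compound 1 to compound 3 (0.06 log units; that floor lies within the scatter). Between the two limits the step is a step that the two limits leave unreadable from compound 2 to compound 3. Neither readable floor leaves the scatter, so in this assay no step beyond the scatter is expected for compound 4, and a limit rather than a number is the likelier outcome. The expected step is a 1.2-fold higher number from compound 1 to compound 4 (0.09 log units; within the scatter). Compound 4 is estimated at 260000 nM, with a range from 120000 nM to 550000 nM.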

Compound 4, half-maximal inhibitory concentration: > 262000 nM
Compound 4 gave a limit, no number (the forecaster's own chance of this, stated with the estimate: 60%); middle value at least 1.0-fold (0.00 log units) from the limit.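

In this assay compound 4 ends at a limit of the assay, not a number: the limit of > 262000 nM in this assay, at which 1 of the 4 values shown sits. Putting 1-hydroxyethyl in place of 2-carboxyethyl on this saturated chain carbon gives an at least 1.2-fold higher number from compound 1 to compound 4 (0.09 log units; that floor lies within the scatter), a floor only, and the steps from compound 2 and compound 3 to compound 4 cannot be read. Hydrogen, 4-aminobutyl and now 1-hydroxyethyl at this place all end in limits, so a side chain with a hydroxyl joins those with an amine or none at all. Within the data shown here, compound 1 gives 210000 nM, still the only number.

As far as these compounds go, what a benzyl group or a longer chain ending in a carboxylic acid would give at this place stays open. From the compounds shown here alone, the true size of each step in this assay also stays open, with three of the four compounds given only as limits.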